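Moving the carbamoyl group around the phenyl ring

This account rests on a few compounds, and the source may have more. Where it says the series, first, only, none or still open, it means among the compounds named here.

Three compounds share a core built from compound 1 `O=C(CCCCCCc1ccccc1)c1ncc(-c2ccccc2C(=O)C(F)(F)F)o1`, in which the phenyl ring carries a trifluoroacetyl group; in an assay (Rattus norvegicus) for inhibition of Fatty-acid amide hydrolase 1 (Homo sapiens) (on this read-out higher numbers stand for weaker inhibition and lower numbers for stronger inhibition), compound 1 gives 5000 nM. Compound 2 `COC(=O)c1cccc(-c2cnc(C(=O)CCCCCCc3ccccc3)o2)c1` carries a methyl ester instead and gives 12 nM in this assay. Compound 3 `NC(=O)c1cccc(-c2cnc(C(=O)CCCCCCc3ccccc3)o2)c1` carries a primary amide and gives 6 nM in this assay. Compound 3 gives the lowest of the three numbers, but the step of a 2.0-fold lower number from compound 2 to compound 3 (0.30 log units; within the scatter) lies within the scatter, so compound 2 and compound 3 cannot be told apart; compound 1, by contrast, stands far beyond the scatter from compound 3.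

Compound 4 `NC(=O)c1ccc(-c2cnc(C(=O)CCCCCCc3ccccc3)o2)cc1` has not yet been measured. It differs from compound 3 by 4-carbamoylphenyl in place of 3-carbamoylphenyl on an aromatic carbon: the same atoms, joined differently, with the amide moved to another position of the phenyl ring. For the measured compounds named here, no measured step moves a group around this ring; the only measured step, from compound 2 to compound 3, swaps one group for another at a fixed position and is within the scatter. The data therefore give no direction for this change, and a step of a 2.0-fold higher number from compound 3 to compound 4 (0.30 log units; within the scatter) is expected, with a wide range. Compound 4 is estimated to give 12 nM in this assay, between 2 nM and 80 nM.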

Compound 4, inhibition constant: 10 nM
For compound 4 the middle estimate is 1.2-fold (0.08 log units) above the measured one; the measured number falls inside the stated range.
By their numbers in this assay, from the lowest: compounds 3, 4 and 2 (each within the scatter of the next); then compound 1.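

Moving the amide from 3-carbamoylphenyl to 4-carbamoylphenyl gives the first measured change of position on this phenyl ring: in this assay the move gives a 1.7-fold higher number from compound 3 to compound 4 (0.22 log units; within the scatter) and so leaves the two compounds indistinguishable. For this pair, then, the read-out does not separate the two placements of the amide, even though the change rearranges the same atoms and alters nothing in the counts of atoms, donors or acceptors. Nothing measured here accounts for why the two placements read alike.

On these data alone, it remains open whether this lack of a clear difference extends beyond the primary amide, for instance to a carboxylic acid, an amine or a nitrile carried at these same two places on the phenyl ring. For the compounds shown here, it also remains open whether the two placements would still read alike with a longer chain on the carbonyl of the shared core, since every comparison of position so far rests on this one pair with a single chain.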